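Vinyl in place of ethyl on compound 3

The source may report more compounds than this note shows. Statements on the series, on what has been measured and on what is new or still open speak of the compounds shown alone.

In a functional assay on MCF7 cells (Homo sapiens) for inhibition, read by colorimetric assay and MTT assay, with a stated time of 72 h (on this read-out lower numbers stand for stronger inhibition and higher numbers for weaker inhibition), compound 1 (`COc1ccc2c(c1)-c1cnc(n1C)OCCCCCCCCO2`) gives 32000 nM and compound 2 (`Cn1c2cnc1OCCCCCCCCOc1ccc(F)cc1-2`) gives 52000 nM. Among the measured compounds shown here, the one measured step, a 1.6-fold higher number from compound 1 to compound 2 (0.21 log units; within the scatter), is fluoro in place of methoxy on an aromatic carbon, so it bears only loosely on the change considered here. Compound 3 (`CCCCOc1ncc(-c2ccccc2OC)n1C`) gives 55000 nM, within the scatter of both. Compound 4 (`C=CCCOc1ncc(-c2ccccc2OC)n1C`) differs from compound 3 by vinyl in place of ethyl on a saturated chain carbon, two bonds along the chain from an oxygen on an aromatic ring, which reads as butoxy to (but-3-en-1-yl)oxy. For the measured compounds named here, no measured step covers this change, so no shift beyond the scatter is expected in this assay. The estimated step is a 1.1-fold lower number from compound 3 to compound 4 (0.06 log units; within the scatter). For compound 4 the expected value is 48000 nM, with an estimated range of 22000 nM to 100000 nM.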

Compound 4, half-maximal inhibitory concentration: 27000 nM
For compound 4 the middle estimate is 1.8-fold (0.25 log units) above the measured one; the range from low to high includes it.
By their numbers in this assay, from the lowest: compounds 4, 1, 2 and 3 (each within the scatter of the next, the first and the last beyond it).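

Butoxy to (but-3-en-1-yl)oxy gives a 2.0-fold lower number from compound 3 to compound 4 (0.31 log units; beyond the scatter) in this assay, the only step in the series so far that lies beyond the scatter. This chain position therefore responds to a change that keeps the heavy-atom count and adds one double bond outside aromatic rings, although the step is modest. Nothing available explains the step.

From the compounds shown here alone, whether a terminal alkyne, a longer chain or an amine at this place would move the number further remains open. A single pair also leaves open whether the double bond matters in itself.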